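This account rests on a few compounds, and the source may have more. Where it says the series, first, only, none or still open, it means among the compounds named here.

Among the compounds with values here, compound 1 `ClCc1ccc(Cn2cnc3c(Cl)ncnc32)cc1` gives 10200 nM in a functional assay on Hs-578T cells (Homo sapiens) for cytotoxicity, read by sulforhodamine B assay, with a stated time of 48 h (on this read-out lower numbers stand for stronger inhibition of growth and higher numbers for weaker inhibition of growth), the highest of the three numbers so far. Compound 2 `ClCc1cccc(Cn2cnc3nc(Cl)nc(Cl)c32)c1` gives 1410 nM and compound 3 `ClCc1ccccc1Cn1cnc2nc(Cl)nc(Cl)c21` gives 670 nM in this assay, both beyond the scatter from compound 1; each carries two chloro groups on the core, where compound 1 carries one. Compound 4 `ClCc1ccc(Cn2cnc3c(Cl)nc(Cl)nc32)cc1` differs from compound 1 by chloro in place of hydrogen on an aromatic carbon, so its core now carries two chloro groups while the rest of compound 1 is kept. The second chloro on the core goes with the lower numbers of compound 2 and compound 3, so a step toward lower numbers, beyond the scatter, is expected from compound 1 to compound 4, estimated at a 5.1-fold lower number from compound 1 to compound 4 (0.71 log units; beyond the scatter). For compound 4 the expected value in this assay is 2000 nM, with a range from 600 nM to 6500 nM.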

Compound 4, concentration for 50% growth inhibition: 2140 nM
Estimate against measurement, compound 4: 1.1-fold (0.03 log units) below, within the range that was stated.
By their numbers in this assay, from the lowest: compound 3; then compounds 2 and 4 (each within the scatter of the next); then compound 1.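

Chloro in place of hydrogen on the aromatic carbon between two ring nitrogen atoms gives a 4.8-fold lower number from compound 1 to compound 4 (0.68 log units; beyond the scatter) in this assay as a modest change beyond the scatter. Within the data shown here, compound 1 and compound 4 differ in this one place, so the effect of this added chloro can be read directly, which the earlier compounds did not allow. No evidence on the origin of this step is available.

From the compounds shown here alone, an amine or a methoxy group at this position remains open, as does whether the step holds with the chloromethyl group placed elsewhere.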